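Hydroxyphenyl Position Swap on a Pyridine-Type Core

The source may report more compounds than this note shows. Statements on the series, on what has been measured and on what is new or still open speak of the compounds shown alone.

Compound 1, `Oc1cccc(-c2cc(-c3ccc(F)cc3)cc(-c3ccccc3O)n2)c1`, in a functional assay on HCT-15 cells (Homo sapiens) for inhibition (a higher number here means a weaker inhibitor, a lower number a stronger inhibitor), gives > 50000 nM, which is a limit of the assay and not a number.
Compound 2, `Oc1ccc(-c2cc(-c3ccc(F)cc3)cc(-c3ccccc3O)n2)cc1`, gives > 50000 nM, again a limit and not a number.
Among the measured compounds shown here, compound 3, `Oc1cccc(-c2cc(-c3ccccc3OC(F)(F)F)cc(-c3ccccc3O)n2)c1`, gives 3240 nM, the only number among the three.

The step from compound 1 to compound 2 is a step that the two limits leave unreadable from compound 1 to compound 2; its size cannot be read because the limit of > 50000 nM in this assay, at which 2 of the 3 values shown sit, holds both of them. The change itself is 4-hydroxyphenyl in place of 3-hydroxyphenyl on an aromatic carbon. How the core of compound 3 differs from that of compound 1 is not broken down here.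

Compound 4, `Oc1ccc(-c2cc(-c3ccccc3OC(F)(F)F)cc(-c3ccccc3O)n2)cc1`, has not yet been measured in this assay. It differs from compound 3 by 4-hydroxyphenyl in place of 3-hydroxyphenyl on an aromatic carbon, the same kind of change as from compound 1 to compound 2, though the surroundings are not the same: in the earlier pair the place is meta to a 4-fluorophenyl group (7 heavy atoms), here it is meta to a large group. Since the earlier step gave no readable size, there is no measured guide to how large the step from compound 3 to compound 4 should be. The writer expects a step of a 1.9-fold higher number from compound 3 to compound 4 (0.27 log units; within the scatter), resting on the value of compound 3 at 3240 nM and on the absence of any readable precedent. Compound 4 is therefore expected to fall near 6000 nM, with a wide range from 1500 nM to 30000 nM.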

Compound 4, half-maximal inhibitory concentration: 9820 nM
Compound 4: the middle estimate sits 1.6-fold (0.21 log units) below what was measured; the range from low to high includes it.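

In this assay, putting 4-hydroxyphenyl in place of 3-hydroxyphenyl on the core carrying the trifluoromethoxyphenyl group gives a 3.0-fold higher number from compound 3 to compound 4 (0.48 log units; beyond the scatter), so on this core the change has a readable size and direction. The same change on the core carrying the 4-fluorophenyl group cannot be read, because compound 1 and compound 2 both stand at a value that is a limit of the assay and not a number: the limit of > 50000 nM in this assay, at which 2 of the 4 values shown sit. The series therefore offers one readable instance of this change, which shows what it does on one core but not whether its size or direction carries over to the other, so nothing here establishes a transfer between cores.

The compounds shown leave open whether the step seen on the core of compound 3 would recur on a third core, since two cores, one of them unreadable, cannot define a trend. They also leave open how far the result depends on the hydroxyl itself: an amine or a carboxylic acid on that same phenyl ring, in place of the hydroxyl, would show whether compound 3 and compound 4 mark a general preference or one confined to this group.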